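The compounds below may be only part of what the source reports. "The series", "measured", "known", "first", "only" and "open" are said of these compounds alone.

Measured so far in a physicochemical assay for lipophilicity, read by HPLC, in phosphate buffer, measured as chromatographic lipophilicity, at pH 7.4; a lower number here means a more polar compound, a higher number a more lipophilic compound:
compound 1 `COc1ccc2nc(C)cc(OCCNc3cc(C)cc(C)c3)c2c1` gives 6.93;
compound 2 `COc1ccc2nc(C)cc(NCC(=O)Nc3cc(C)cc(C)c3)c2c1` gives 3.59;
compound 3 `COc1ccc2nc(C)cc(OCC(=O)Nc3cc(C)ccc3OC)c2c1` gives 5.65.

Among these three, compound 3 stands second highest. Compound 1 lies above it by a margin beyond the usual scatter, and compound 2 lies below it by a wider margin, also beyond the scatter. All three share a core and differ only in the chain and the ring hung on it.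

Compound 4 `COc1ccc2nc(C)cc(OCC(=O)Nc3noc(C)c3C)c2c1` has not yet been measured. It differs from compound 3 in a single place: 4,5-dimethyl-1,2-oxazol-3-yl in place of 2-methoxy-5-methylphenyl on an amide-type nitrogen. The group that leaves is a six-membered aromatic ring of carbon only with one hydrogen-bond acceptor; the group that enters is a smaller five-membered aromatic ring with two hetero atoms and two hydrogen-bond acceptors, on the same amide-type nitrogen. Going by the values given here, no measured pair in this set shows this particular exchange, so the size of the step cannot be read off from a neighbour and has to be judged from the structures alone. In this assay the step is expected to be downward and to exceed the scatter, since a ring with more hetero atoms and fewer carbons usually reads as more polar. Compound 4 is therefore estimated at 4.4, most likely between 3.7 and 5.1. This estimate implies an expected step from compound 3 to compound 4 of a number 1.25 log units lower from compound 3 to compound 4 (beyond the scatter).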

Compound 4, distribution coefficient: 3.3
For compound 4 the middle estimate is 1.10 log units above the measured one; the measured number lies below the stated range.
By their numbers in this assay, from the lowest: compounds 4 and 2 (each within the scatter of the next); then compound 3; then compound 1.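

In this assay, going by these compounds alone, putting 4,5-dimethyl-1,2-oxazol-3-yl in place of 2-methoxy-5-methylphenyl on the amide-type nitrogen gives a number 2.35 log units lower from compound 3 to compound 4 (beyond the scatter) and provides the first comparison in this set that changes only one place. The earlier compounds shown here differed in more than one place, so they could not isolate this group. This pair shows that with the chain and shared core unchanged, the exchange alone produces a large drop in the read-out. Nothing measured here explains why the step is so large.

This single exchange changes the ring and its substituents together, so their separate contributions remain unresolved. As far as these compounds go, it also remains open how the read-out would respond to a plain phenyl ring, or to a group carrying an amine or a carboxylic acid, on the same nitrogen.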